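Phenyl to 4-chlorophenyl at the assay limit

The source may report more compounds than this note shows. Statements on the series, on what has been measured and on what is new or still open speak of the compounds shown alone.

In a functional assay on HepG2 cells (Homo sapiens) for inhibition, read by sulforhodamine B assay, with a stated time of 74 h (a higher number here means a weaker inhibitor, a lower number a stronger inhibitor), compound 2 `O=C1C=CC2(C=C1)OCC(=O)N2S(=O)(=O)c1ccccc1` gives > 10000 nM, which is a limit and not a number. Compound 1 `Cc1ccc(S(=O)(=O)N2C(=O)COC23C=CC(=O)C=C3)cc1` gives > 10000 nM, also a limit. Compound 3 `Cc1ccc(S(=O)(=O)N2C(=O)C(C)OC23C=CC(=O)C=C3)cc1` gives a measured 540 nM.

Compound 4 `O=C1C=CC2(C=C1)OCC(=O)N2S(=O)(=O)c1ccc(Cl)cc1` carries chloro in place of hydrogen on an aromatic carbon, chloro in place of hydrogen on an aromatic carbon. Within the data shown here, the only measured change on an aromatic carbon is a step that the two limits leave unreadable from compound 1 to compound 2, so it offers no size to carry over. The other measured change is an at least 18-fold lower number from compound 1 to compound 3 (1.26 log units; beyond the scatter), but it lies on a saturated ring carbon and does not apply directly here.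

The expected change in this assay is a number no higher from compound 2 to compound 4 (the limit leaves the size open), with no clear shift beyond the scatter anticipated. Compound 4 is estimated at 10000 nM, with an expected range of 3000 nM to 30000 nM.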

Compound 4, half-maximal inhibitory concentration: 860 nM
For compound 4 the middle estimate is 12-fold (1.07 log units) above the measured one, outside the stated range (below it).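

Chloro in place of hydrogen on an aromatic carbon, para to a large group, gives the first readable step at this position in this assay (an at least 11-fold lower number from compound 2 to compound 4 (1.06 log units; beyond the scatter)). Chloro in place of methyl at the same place also reads (an at least 11-fold lower number from compound 1 to compound 4 (1.06 log units; beyond the scatter)), while the step from methyl to hydrogen there cannot be read. Both readable steps stay open in size because each starts from a limit: the limit of > 10000 nM in this assay, at which 2 of the 4 values shown sit.

On these data alone, what an amine or a carboxylic acid would give at this place stays open. So does whether chloro would combine with the methyl on the saturated ring carbon of compound 3.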